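Chlorophenyl thiourea sulfonamides: cytotoxicity notes

The compounds below may be only part of what the source reports. "The series", "measured", "known", "first", "only" and "open" are said of these compounds alone.

Measured so far in an ADME assay on HEK-293T cells (Homo sapiens) for cytotoxicity, read by CCK-8 assay, with a stated time of 48 h; on this read-out higher numbers stand for weaker inhibition and lower numbers for stronger inhibition:
- compound 1 `O=C(NCCNS(=O)(=O)c1ccc(-c2ccccc2Oc2ccc(O)c(O)c2)s1)Nc1cc(Cl)cc(Cl)c1`: 12400 nM.
- compound 2 `O=C(NCCNS(=O)(=O)c1cc(-c2ccccc2Oc2ccc(O)c(O)c2)cs1)Nc1cc(C(F)(F)F)cc(C(F)(F)F)c1`: > 50000 nM.
- compound 3 `O=S(=O)(NCCNC(=S)Nc1cccc(Cl)c1)c1ccc(-c2ccccc2OCc2ccccc2)s1`: 10200 nM.

The entry of compound 2 is a limit of the assay rather than a number, which is where the limit of > 50000 nM in this assay, at which 1 of the 3 values shown sits, stands. Among the two numbers shown, compound 3 gives 10200 nM and compound 1 gives 12400 nM; the gap between them lies within the usual scatter, so neither is told apart from the other. For the measured compounds named here, compound 3 also differs from compound 1 in more than one place, so no step between them can be read.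

The next compound, compound 4 `O=S(=O)(NCCNC(=S)Nc1ccc(Cl)cc1)c1ccc(-c2ccccc2OCc2ccccc2)s1`, shares everything with compound 3 except the position of the chlorine on the ring attached to the thiocarbonyl carbon: 4-chlorophenyl in place of 3-chlorophenyl on an amide-type nitrogen. Going by the values given here, no measured pair shows the effect of moving a chlorine on this ring. With no evidence for a shift, the expected step of a 1.0-fold lower number from compound 3 to compound 4 (0.01 log units; within the scatter) is none beyond the scatter. Compound 4 is therefore estimated at 10000 nM, with a range from 4000 nM to 25000 nM.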

Compound 4, half-maximal inhibitory concentration: 12100 nM
For compound 4 the middle estimate is 1.2-fold (0.08 log units) below the measured one; low and high end bracket the measured number.
By their numbers in this assay, from the lowest: compounds 3, 4 and 1 (each within the scatter of the next). At a limit, above all of these: compound 2.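

Working notes on the chlorine position: in this assay, the series gives its first readable step, a 1.2-fold higher number from compound 3 to compound 4 (0.07 log units; within the scatter), with 4-chlorophenyl in place of 3-chlorophenyl on the amide-type nitrogen. On this read-out the two placements of the chlorine are not told apart, so this change at this nitrogen has no effect that can be read beyond the scatter. Nothing shown bears on a cause for this step.

Still open, going by these compounds, is whether a group other than chlorine on this ring, such as an amine or a carboxylic acid, would move the number beyond the scatter. Also open, on these data alone, is whether a carbonyl in place of the thiocarbonyl would change the number on the otherwise unchanged core of compound 3.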